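The source may report more compounds than this note shows. Statements on the series, on what has been measured and on what is new or still open speak of the compounds shown alone.

Compound 2 `Cc1ccc(S(=O)(=O)N(Cc2nnc(Cc3ccccc3F)o2)c2cccc(Cl)c2C)cc1` gives the highest of the two numbers measured in an assay on CHO cells for displacement of a labelled ligand from prostaglandin E2 receptor EP1 subtype (Homo sapiens); on this read-out higher numbers stand for weaker inhibition and lower numbers for stronger inhibition; its nearest neighbour, compound 1 `COc1ccc(Cc2nnc(CN(c3cccc(Cl)c3C)S(=O)(=O)c3ccc(C)cc3)o2)cc1`, gives 6.31 nM, whereas compound 2 gives 501 nM. For the measured compounds named here, the only step measured, a 79-fold higher number from compound 1 to compound 2 (1.90 log units; beyond the scatter), swaps a different group and does not test the change at hand. Compound 3 `Cc1ccc(S(=O)(=O)N(Cc2nnc(Cc3ccccc3Cl)o2)c2cccc(Cl)c2C)cc1` differs from compound 2 by chloro in place of fluoro on an aromatic carbon, sitting ortho to a large group. Going by the values given here, no measured step bears on this change, so for compound 3 the expected step is a 1.3-fold lower number from compound 2 to compound 3 (0.10 log units; within the scatter), within the scatter. Compound 3 is therefore estimated at 400 nM, with a range from 130 nM to 1300 nM.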

Compound 3, half-maximal inhibitory concentration: 79.4 nM
Compound 3: the middle estimate sits 5.0-fold (0.70 log units) above what was measured; measured number below the stated range.
By their numbers in this assay, from the lowest: compound 1; then compound 3; then compound 2.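

Fluoro and chloro each count as a single heavy atom, yet this one exchange on an aromatic carbon, ortho to a large group, gives a 6.3-fold lower number from compound 2 to compound 3 (0.80 log units; beyond the scatter) and so shows that this position is sensitive to which halogen it carries. The 2-chlorophenyl group still falls short of the 4-methoxyphenyl group, with a 13-fold higher number from compound 1 to compound 3 (1.10 log units; beyond the scatter) remaining between them. Nothing measured here explains the effect of the halogen exchange. The compounds shown leave open whether bromo or methyl on this same carbon would lower the number further.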